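Thioether aryl swap in the acrylamide series

The source may hold more compounds than are shown below. What is called first, only, known or untested is meant among the compounds shown, and "the series" means these compounds.

compound 1: `Nc1ccccc1NC(=O)/C=C/c1ccc(CSc2ccc(F)cc2)cc1` — 24.6%
compound 2: `Nc1ccccc1NC(=O)c1ccc(CSc2cccc(F)c2)cc1` — 76.3%
compound 3: `CC(C)(C)c1ccc(SCc2ccc(C(=O)Nc3ccccc3N)cc2)cc1` — 33.1%

All three were run in a functional assay on A-375 cells (Homo sapiens) for inhibition, read by CCK-8 assay, with a stated time of 72 h, tested at 8 uM; on this read-out lower numbers stand for less inhibition of growth and higher numbers for more inhibition of growth at the one concentration tested. Compound 1 gives the lowest of the three numbers; compound 3 stands within the usual scatter of it, while compound 2 stands well beyond it. Going by the values given here, no two measured compounds differ in only one place, so no single-change step is available to guide the next move.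

Compound 4 `Nc1ccccc1NC(=O)/C=C/c1ccc(CSc2ccc(C(F)(F)F)cn2)cc1` is not yet measured. It differs from compound 1 by 5-(trifluoromethyl)pyridin-2-yl in place of 4-fluorophenyl on a sulfur. Among the compounds with values here, with no comparable step among the measured compounds, the step implied by the estimate, a number 5.4 percentage points higher from compound 1 to compound 4 (within the scatter), is expected to be small and not clearly beyond the scatter. Compound 4 is expected to give 30% in this assay, with a range from 10% to 55%.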

Compound 4, percent growth inhibition at one concentration: 3.96%
Compound 4: middle estimate off by 26 percentage points, on the high side; the whole stated range lies above it.
By their numbers in this assay, from the lowest: compound 4; then compounds 1 and 3 (each within the scatter of the next); then compound 2.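

Going by these compounds alone, the first single-change step falls on the aryl group on a sulfur: in this assay, 5-(trifluoromethyl)pyridin-2-yl in place of 4-fluorophenyl gives a number 20.6 percentage points lower from compound 1 to compound 4 (beyond the scatter). The number at this position therefore responds to the aryl group, and here the swap lowers it beyond the scatter. Nothing measured here accounts for the drop.

The change alters the ring and its substituent together, so their separate contributions remain unresolved. A pyridine ring without trifluoromethyl, or a phenyl ring carrying trifluoromethyl, would separate them on the shared core.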